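This account rests on a few compounds, and the source may have more. Where it says the series, first, only, none or still open, it means among the compounds named here.

Measured so far: compound 1 `c1ccc(-c2nc[nH]n2)c(NCC2=NCCN2)c1` gives 5.01 nM in an in vitro functional assay on cells (Fibroblast) for agonist activity at Alpha-1B adrenergic receptor (Homo sapiens); a higher number here means that more compound is needed for the effect, a lower number that less compound is needed; compound 2 `Cn1ncnc1-c1ccccc1NCC1=NCCN1` gives 39.8 nM in this assay.

Compound 2 stands at the higher of the two numbers, so more of it is needed than of compound 1. Among the measured compounds shown here, the single step that joins them, a 7.9-fold higher number from compound 1 to compound 2 (0.90 log units; beyond the scatter), came with a methyl moved onto a ring nitrogen.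

Compound 3 `Cc1n[nH]c(-c2ccccc2NCC2=NCCN2)n1` has not yet been measured. It differs from compound 2 in one place: 3-methyl-1H-1,2,4-triazol-5-yl in place of 1-methyl-1H-1,2,4-triazol-5-yl on an aromatic carbon. The methyl stays, but on a carbon of the five-membered ring, and a ring nitrogen again carries a hydrogen, as in compound 1.

For the measured compounds named here, only one measured step bears on this, the one from compound 1 to compound 2. It showed that putting the methyl on the ring nitrogen raised the number; compound 3 undoes that part of the change while keeping a methyl elsewhere on the ring. The expectation is therefore a drop in this assay of a 5.0-fold lower number from compound 2 to compound 3 (0.70 log units; beyond the scatter), back toward compound 1, though a methyl on the ring remains and the exact return is uncertain. Compound 3 is estimated at 8 nM, within 3 nM to 25 nM.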

Compound 3, half-maximal effective concentration: < 5020 nM
Compound 3 was reported as a limit; the forecaster's own chance of this, stated with the estimate: 2%; the middle value does not contradict the limit.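

In this assay compound 3 is reported only as a limit, < 5020 nM, and not as a number. Its steps from compound 2 and from compound 1 therefore cannot be read. The compounds shown leave open whether moving the methyl onto a carbon of the five-membered aromatic ring brings the number back toward that of compound 1.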